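This account rests on a few compounds, and the source may have more. Where it says the series, first, only, none or still open, it means among the compounds named here.

Compound 3 `COc1ccc(C(=O)Nc2nc3c(OC)cccc3s2)cc1` gives 1.25 ug/mL in a functional assay on MDA-MB-231 cells (Homo sapiens) for antiproliferative activity, read by sulforhodamine B assay (on this read-out lower numbers stand for stronger inhibition of growth and higher numbers for weaker inhibition of growth), the lowest of the two numbers in hand. Compound 1 `O=C(Nc1nc2ccc([N+](=O)[O-])cc2s1)c1ccc(C(F)(F)F)cc1` gives 1.89 ug/mL in this assay, a value within the scatter of compound 3, so the two cannot be ordered. Compound 2 `COc1cccc2sc(NC(=O)c3ccc(C(F)(F)F)cc3)nc12` gives > 10 ug/mL in this assay, which is a limit and not a number. Going by the values given here, the only step measured on the ring that carries the amide carbonyl is an at least 8.0-fold lower number from compound 2 to compound 3 (0.90 log units; beyond the scatter), a change beyond the scatter, with the starting point sitting at the assay limit (the limit of > 10 ug/mL in this assay, at which 1 of the 3 values shown sits).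

Compound 4 `COc1cccc2sc(NC(=O)c3ccc(C#N)cc3)nc12` differs from compound 3 in that (cyano in place of methoxy on an aromatic carbon). Among the compounds with values here, no measured pair compares cyano with methoxy, and none compares cyano with trifluoromethyl, so the step from compound 2 to compound 3 bears on it only in showing that this position is sensitive to the group it carries. Cyano is neither of the groups measured there, so the direction is uncertain and the expected range is wide. Compound 4 is expected to give 4 ug/mL in this assay, within 1.2 ug/mL to 12 ug/mL. The expected step from compound 3 to compound 4 is a 3.2-fold higher number from compound 3 to compound 4 (0.51 log units; beyond the scatter), with a real chance that only a limit is reported.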

Compound 4, concentration for 50% growth inhibition: > 10 ug/mL
Compound 4 gave a limit, no number; the forecaster's own chance of this, stated with the estimate: 35%; middle value at least 2.5-fold (0.39 log units) from the limit.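

On the aromatic carbon para to a large group, the change from methoxy to cyano in this assay gives an at least 8.0-fold higher number from compound 3 to compound 4 (0.90 log units; beyond the scatter), which is beyond the scatter. The earlier compounds shown here tested only one replacement for methoxy here, and this result adds a second: of the three groups now seen at this place on the shared core, only methoxy, in compound 3, gives a number rather than a limit. Trifluoromethyl in compound 2 and cyano in compound 4 cannot be ordered, and the step between them cannot be read, because each result is only a limit: the limit of > 10 ug/mL in this assay, at which 2 of the 4 values shown sit.

Going by these compounds, it remains open whether a measurable value at this place is peculiar to methoxy or would also appear with an amine, a hydroxyl or an ethoxy group. Also unresolved is whether the same change from methoxy to cyano would have a comparable effect on the core of compound 1, which carries a nitro group in place of the methoxy on the shared core.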